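The compounds below may be only part of what the source reports. "The series", "measured", "known", "first", "only" and "open" are said of these compounds alone.

Measured in an assay for displacement of a labelled ligand from Sigma non-opioid intracellular receptor 1 (Cavia porcellus); a lower number here means a stronger inhibitor, a higher number a weaker inhibitor:

compound 1 `COC(=O)C1(c2ccc(Cl)cc2)CC1CN1CCN(c2ccccn2)CC1`: 707 nM
compound 2 `COC(=O)C1(c2ccc([N+](=O)[O-])cc2)CC1CN1CCC(Cc2ccccc2)CC1`: 0.68 nM
compound 3 `COC(=O)C1(c2ccc(Cl)cc2)CC1CN1CCN(c2ncccn2)CC1`: 350 nM

Compound 1 stands at the highest of the three numbers in this assay. Its nearest neighbour is compound 3, which differs only in the aryl group on the amine nitrogen of the ring: a 2.0-fold lower number from compound 1 to compound 3 (0.31 log units; beyond the scatter). Compound 2 lies far from both, but it differs from compound 1 in two places at once, so its much lower number cannot be assigned to either change.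

Compound 4 `COC(=O)C1(c2ccc(N)cc2)CC1CN1CCN(c2ccccn2)CC1` is compound 1 with one alteration: amino in place of chloro on an aromatic carbon. Within the data shown here, no measured pair isolates this change. Among the measured compounds shown here, the only single-point step in the set, the one from compound 1 to compound 3, concerns the other end of the molecule, and the pair of compounds 1 and 2 confounds the aryl substituent with the amine. For the measured compounds named here, the expectation for compound 4 in this assay therefore rests on no direct precedent, and the estimate is kept near compound 1 with a wide range. A modest rise in the number is expected, a 2.1-fold higher number from compound 1 to compound 4 (0.33 log units; beyond the scatter). Compound 4 is estimated at 1500 nM, with a range from 400 nM to 6000 nM.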

Compound 4, inhibition constant: > 10000 nM
Compound 4 gave a limit, no number; the forecaster's own chance of this, stated with the estimate: 15%; at least 6.6-fold (0.82 log units) between middle value and limit.
By their numbers in this assay, from the lowest: compound 2; then compound 3; then compound 1. At a limit, above all of these: compound 4.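

In this assay, compound 4 gives > 10000 nM, which is a limit of the assay and not a number. This is the first single-point change shown at the aryl substituent, and 4-chlorophenyl to 4-aminophenyl gives an at least 14-fold higher number from compound 1 to compound 4 (1.15 log units; beyond the scatter), a large step, whereas the change at the other end of the molecule gave only a modest one, a 2.0-fold lower number from compound 1 to compound 3 (0.31 log units; beyond the scatter). The position on the aromatic carbon, para to a large group, is therefore not indifferent to what sits there in this series, and the size of the step can be read only as a minimum because the value of compound 4 sits at the assay limit: the limit of > 10000 nM in this assay, at which 1 of the 4 values shown sits.

From the compounds shown here alone, it remains open whether the loss follows from the arrival of amino or from the departure of chloro, and a bare hydrogen, a fluoro, a methoxy or an acetylated amine at this position would help to separate the two. Also open, going by these compounds, is whether amino has the same effect with the pyrimidin-2-yl group of compound 3 or with the amine of compound 2, whose nitro group cannot be read alone since that compound differs from compound 1 in two places.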